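This account rests on a few compounds, and the source may have more. Where it says the series, first, only, none or still open, it means among the compounds named here.

Measured in a functional assay on BGC-823 cells (Homo sapiens) for cytotoxicity, read by MTT assay, with a stated time of 48 h; on this read-out lower numbers stand for stronger inhibition and higher numbers for weaker inhibition:
- compound 1 `CCCCOc1ccc2c(Cl)ccnc2c1`: 3610 nM
- compound 2 `CCCCCCCCOc1ccc2c(Cl)ccnc2c1`: 4300 nM

Not yet measured:
- compound 3 `Clc1ccnc2cc(OCc3ccccc3)ccc12`

For the measured compounds named here, compound 1 has only one measured neighbour, and the two values do not separate: a 1.2-fold higher number from compound 1 to compound 2 (0.08 log units; within the scatter). Compound 3 differs by phenyl in place of propyl on a saturated chain carbon bound to an oxygen on an aromatic ring. Going by the values given here, one measured step bears on this, the butyl in place of hydrogen on the same chain, which gave a 1.2-fold higher number from compound 1 to compound 2 (0.08 log units; within the scatter). Among the compounds with values here, that step did not involve a ring, and no measured compound carries one at this place, so the evidence is thin. No step beyond the scatter is therefore expected in this assay, and the range is kept wide. The expected change is a 1.1-fold higher number from compound 1 to compound 3 (0.04 log units; within the scatter). For compound 3 the estimated value is 4000 nM, with an expected range of 1500 nM to 10000 nM.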

Compound 3, half-maximal inhibitory concentration: 5170 nM
Compound 3: the middle estimate sits 1.3-fold (0.11 log units) below what was measured; the measured number falls inside the stated range.
By their numbers in this assay, from the lowest: compounds 1, 2 and 3 (each within the scatter of the next).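

Phenyl in place of propyl on a saturated chain carbon bound to an oxygen on an aromatic ring gives a 1.4-fold higher number from compound 1 to compound 3 (0.16 log units; within the scatter) in this assay, so a ring at this place does not separate from the chain of compound 1. For the compounds shown here, until this result, the only step at this place was a chain extension; the series now shows that neither lengthening the chain nor swapping its end for a six-membered aromatic ring of carbon only moves the number beyond the scatter. Nothing available accounts for this insensitivity.

Every group shown at this place contains carbon and hydrogen only, so an amine or a carboxylic acid on the chain remains an open case. Also open, from the compounds shown here alone, is whether a substituent such as a methoxy group on the phenyl ring would give a step beyond the scatter.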